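This account rests on a few compounds, and the source may have more. Where it says the series, first, only, none or still open, it means among the compounds named here.

Compound 2 `CN1CCCN(CCn2ccc3ccc(Cl)cc32)CC1` gives 34 nM in an assay on HEK293 cells for binding affinity to 5-hydroxytryptamine receptor 7 (Homo sapiens), read by radioligand binding; a higher number here means a weaker inhibitor, a lower number a stronger inhibitor. Among the three measured compounds it holds the second-highest number: compound 1 `Brc1ccc2ccn(CCN3CCCN4CCCCC4C3)c2c1` sits furthest away with 3 nM, and compound 3 `CN1CCCN(CCn2ccc3ccc(OCc4ccccc4)cc32)CC1` sits nearest with 182 nM. Compound 4 `CCc1ccc2ccn(CCN3CCCN(C)CC3)c2c1` differs from compound 2 by ethyl in place of chloro on an aromatic carbon. Within the data shown here, the only measured step at this position is a 5.4-fold higher number from compound 2 to compound 3 (0.73 log units; beyond the scatter), where another group replaced the same chloro. Because a 5.4-fold higher number from compound 2 to compound 3 (0.73 log units; beyond the scatter) went upward, a rise in the number for compound 4 is expected too, but a smaller one, since ethyl is a smaller group than benzyloxy and the move may stay within the scatter. Compound 4 is therefore estimated at 60 nM, with a range from 25 nM to 150 nM, which means an expected step of a 1.8-fold higher number from compound 2 to compound 4 (0.25 log units; within the scatter).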

Compound 4, inhibition constant: 166 nM
For compound 4 the middle estimate is 2.8-fold (0.44 log units) below the measured one, outside the stated range (above it).
By their numbers in this assay, from the lowest: compound 1; then compound 2; then compounds 4 and 3 (each within the scatter of the next).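

Ethyl in place of chloro on this aromatic carbon gives a 4.9-fold higher number from compound 2 to compound 4 (0.69 log units; beyond the scatter), so the rise in the number does not need a group as large as benzyloxy. Ethyl in place of benzyloxy gives a 1.1-fold lower number from compound 3 to compound 4 (0.04 log units; within the scatter), so the count of heavy atoms in the group does not order these three compounds: compound 2 stands apart, while compounds 3 and 4 cannot be told apart. No measurement shown here explains this result.

Going by these compounds, whether chloro is special at this position or other groups would perform as well remains open. Fluoro, methoxy or an amine on the same carbon could help to settle this.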